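The compounds below may be only part of what the source reports. "The series", "measured", "known", "first", "only" and "open" are said of these compounds alone.

Among the compounds with values here, compound 2 `O=[N+]([O-])c1ccc(N/C(=N\O)c2cccc(Br)c2)c2nonc12` gives 105 nM in an assay on isolated protein for inhibition of Indoleamine 2,3-dioxygenase 1 (Homo sapiens), read by spectrophotometry, with a stated time of 1 h (a lower number here means a stronger inhibitor, a higher number a weaker inhibitor), the lowest of the two numbers so far; compound 1 `Cc1cccc(/C(=N/O)Nc2ccc([N+](=O)[O-])c3nonc23)c1` gives 163 nM, and the step of a 1.6-fold lower number from compound 1 to compound 2 (0.19 log units; within the scatter) lies within the scatter. Compound 3 `O=[N+]([O-])c1ccc(N/C(=N\O)c2ccc(F)cc2)c2nonc12` is the next case: 4-fluorophenyl in place of 3-bromophenyl on a carbon with a double bond to nitrogen. Within the data shown here, only that one step bears on it, and it stayed within the scatter, so for compound 3 in this assay no step beyond the scatter is expected from compound 2; no measured pair speaks to an exchange of one phenyl for another. The estimate for compound 3 is 220 nM (range 70 nM to 700 nM), meaning a 2.1-fold higher number from compound 2 to compound 3 (0.32 log units; beyond the scatter) is expected.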

Compound 3, half-maximal inhibitory concentration: 100 nM
The estimate for compound 3 lay 2.2-fold (0.34 log units) above the measured number, within the range that was stated.
By their numbers in this assay, from the lowest: compounds 3, 2 and 1 (each within the scatter of the next).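

In this assay the exchange of one phenyl for another on the carbon with a double bond to nitrogen now has measured cases: a 1.1-fold lower number from compound 2 to compound 3 (0.02 log units; within the scatter) and a 1.6-fold lower number from compound 1 to compound 3 (0.21 log units; within the scatter) both stay within the scatter. Across compounds 1, 2 and 3, then, 3-methylphenyl, 3-bromophenyl and 4-fluorophenyl are not told apart at this place. No evidence on the cause is available for this result. Still open, going by these compounds, is whether this holds for a phenyl carrying a carboxylic acid or an amine. On these data alone, a pyridine ring or a longer chain at this place is equally open.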